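Amide nitrogen substituent in a thienylmethyl amide series

The source may hold more compounds than are shown below. What is called first, only, known or untested is meant among the compounds shown, and "the series" means these compounds.

Two compounds of the series have a number in an assay on HEK293 cells for agonist activity at transient receptor potential cation channel subfamily M member 8 (Homo sapiens), read by fluorescence and calcium flux, with a stated time of 15 min; a lower number here means that less compound is needed, a higher number that more compound is needed for the effect. Compound 1 `Cc1ccc(OCC(=O)N(Cc2cccs2)c2ccccn2)cc1` gives 200 nM, the higher of the two. Among the measured compounds shown here, compound 2 `COc1ccc2oc(C(=O)N(Cc3cccs3)c3ccn[nH]3)cc2c1` gives 1.1 nM, a markedly lower number, beyond the scatter; the two structures differ in several places at once, so no single step between them is defined, and the pair only shows the spread of the series. Compound 1 thus stands at the weaker end of what has been measured.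

Compound 3 `CCCN(Cc1cccs1)C(=O)COc1ccc(C)cc1` has not yet been measured. It differs from compound 1 in one place: propyl in place of pyridin-2-yl on an amide-type nitrogen. For the measured compounds named here, the substituent on the amide-type nitrogen is the only variable here, and no measured pair isolates it, so the direction of the step rests on the change alone. Replacing the six-membered aromatic ring by the propyl chain on that nitrogen is expected to cost activity rather than gain it, by a step expected to reach beyond the scatter: a 3.0-fold higher number from compound 1 to compound 3 (0.48 log units; beyond the scatter). Compound 3 is accordingly estimated at 600 nM, with a range from 120 nM to 3000 nM.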

Compound 3, half-maximal effective concentration: 40 nM
The estimate for compound 3 lay 15-fold (1.18 log units) above the measured number, and the stated range ends above it.
By their numbers in this assay, from the lowest: compound 2; then compound 3; then compound 1.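

In this assay, among the compounds shown here, the first step that isolates the substituent on the amide-type nitrogen is a 5.0-fold lower number from compound 1 to compound 3 (0.70 log units; beyond the scatter), so on the core of compound 1 the pyridin-2-yl ring is not needed for activity, and a propyl chain with no ring and no hydrogen-bond acceptor does better at this position. The step is modest but beyond the scatter, which marks this nitrogen as a place where the number responds to the substituent, and it sets a saturated chain as a workable starting point on this core. Nothing on hand explains why the number falls with this change.

One step cannot tell whether the gain belongs to propyl specifically or to saturated chains in general, and an ethyl group, a longer butyl chain, a branched isopropyl group or a cyclohexyl ring on the same nitrogen would each help to define how far it extends. From the compounds shown here alone, it also remains open whether the same exchange would hold on the core of compound 2, which differs from compound 3 in several places at once and so gives no reading of this nitrogen alone.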